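The source may hold more compounds than are shown below. What is called first, only, known or untested is meant among the compounds shown, and "the series" means these compounds.

Working notes on the series. Compound 1 `O=C(O)c1cn(-c2ccc(F)cc2)c2nc(N3CCN(C(=O)C4COc5ccccc5O4)CC3)c([N+](=O)[O-])cc2c1=O`, compound 2 `CC1CN(c2nc3c(cc2[N+](=O)[O-])c(=O)c(C(=O)O)cn3-c2ccc(F)cc2)CC(C)O1`, compound 3 `CC(C)(C)n1cc(C(=O)O)c(=O)c2cc([N+](=O)[O-])c(N3CCN(C(=O)C4COc5ccccc5O4)CC3)nc21` and the unmeasured compound 4 `CC1CN(c2nc3c(cc2[N+](=O)[O-])c(=O)c(C(=O)O)cn3C(C)(C)C)CC(C)O1` are the compounds in hand. In an ADME assay on Vero cells (Chlorocebus sabaeus) for cytotoxicity, read by MTT assay, with a stated time of 72 h (a lower number here means a stronger inhibitor, a higher number a weaker inhibitor), compound 1 gives only a limit of the assay, > 54300 nM. In this assay compound 2 gives 141000 nM and compound 3 gives 116000 nM; these two sit within the scatter of each other. The difference between the core of compound 1 and the core of compound 2 is not broken down here. The change from compound 1 to compound 3 is tert-butyl in place of 4-fluorophenyl on an aromatic nitrogen, and its step is a step that the limit leaves unreadable from compound 1 to compound 3, which cannot be read because of the limit of > 54300 nM in this assay, at which 1 of the 3 values shown sits. The same change, at the same place word for word, is made from compound 2 to compound 4: tert-butyl in place of 4-fluorophenyl on an aromatic nitrogen. In this assay the expected size of this step is a 1.1-fold lower number from compound 2 to compound 4 (0.04 log units; within the scatter), resting on compound 3 at 116000 nM and on compound 2 at 141000 nM, with no readable earlier step to lean on. Compound 4 is therefore estimated at 130000 nM, expected to fall between 50000 nM and 400000 nM.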

Compound 4, half-maximal inhibitory concentration: 159000 nM
Compound 4: middle estimate off by 1.2-fold (0.09 log units), on the low side; measured number inside the range.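

In this assay, tert-butyl in place of 4-fluorophenyl on an aromatic nitrogen gives a 1.1-fold higher number from compound 2 to compound 4 (0.05 log units; within the scatter), so on the core of compound 2 this change does not move the number beyond the scatter. Among the compounds shown here, this is the only readable step for the change, and it holds for one core and one assay, so it gives no pattern that can be claimed across the series. Whether the change carries from one core to another is not shown, as the same change on the core of compound 1 cannot be read, and compound 1 stands only at a limit of the assay, not at a number: the limit of > 54300 nM in this assay, at which 1 of the 4 values shown sits.

The compounds shown leave open whether other groups on that aromatic nitrogen, such as cyclopropyl or a 2-aminoethyl chain, would also stay within the scatter of compound 2. They also leave open how an amine in place of the nitro group would read in this assay on either core.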